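Replacing cyano with methylsulfonyl in a cytotoxic series

The source may report more compounds than this note shows. Statements on the series, on what has been measured and on what is new or still open speak of the compounds shown alone.

In a functional assay on MCF7 cells (Homo sapiens) for cytotoxicity, read by CellTiter-Glo, with a stated time of 5 days (on this read-out higher numbers stand for weaker inhibition and lower numbers for stronger inhibition), compound 1 `CC/C(=C(/c1ccc(/C=C/C(=O)O)c(OC)c1)c1ccc2[nH]ncc2c1)c1ccccc1` gives 31 nM. Compound 2 `CC/C(=C(/c1ccc(/C=C/C(=O)O)cc1)c1ccc2[nH]ncc2c1)c1ccccc1C#N` gives 12 nM, the lower of the two numbers, and the gap between them lies beyond the usual scatter. Compound 3 `CC/C(=C(/c1ccc(/C=C/C(=O)O)cc1)c1ccc2[nH]ncc2c1)c1ccccc1S(C)(=O)=O` has not yet been measured. It differs from compound 2 by having methylsulfonyl in place of cyano on an aromatic carbon. Among the measured compounds shown here, no measured pair shows this change, which leaves the estimate uncertain. The expected step of a 1.8-fold higher number from compound 2 to compound 3 (0.26 log units; within the scatter) is modest and points toward a higher number, meaning weaker inhibition. For compound 3 the estimated value is 22 nM, within a range from 7 nM to 70 nM.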

Compound 3, half-maximal inhibitory concentration: 70 nM
For compound 3 the middle estimate is 3.2-fold (0.50 log units) below the measured one; the range from low to high includes it.
By their numbers in this assay, from the lowest: compound 2; then compound 1; then compound 3.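

In this assay the cyano position on this aromatic ring proves sensitive, as methylsulfonyl in place of cyano gives a 5.8-fold higher number from compound 2 to compound 3 (0.77 log units; beyond the scatter). This single pair places the nitrile ahead of methylsulfonyl at this position, with a higher number meaning weaker inhibition. Nothing available explains why the two groups differ.

What the compounds shown leave open is how other groups would behave at this position, such as an amine, a fluorine atom or a methyl group. They also leave open whether the same change would have a similar effect on a different core.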